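Swapping pyridin-2-yl for thiophen-2-yl in compound 3

The compounds below may be only part of what the source reports. "The series", "measured", "known", "first", "only" and "open" are said of these compounds alone.

- compound 1 `CCCCCCCCc1ccc(OCC(=O)Cn2cnnn2)cc1` gives 22%
- compound 2 `CCCCCCCCc1ccc(OCC(=O)Cn2nnnc2-c2cccnc2)cc1` gives 20%
- compound 3 `CCCCCCCCc1ccc(OCC(=O)Cn2nnnc2-c2ccccn2)cc1` gives < 5% as a limit

All three readings come from an ADME assay on S9 fraction from liver (Rattus norvegicus) for metabolic stability, read by LC-MS, using NADPH, with a stated time of 30 min (a lower number here means that less of the compound is left, a higher number that more of the compound is left), and show how much of each compound is left. Compound 3 gives < 5% in this assay and this is a limit of the assay, not a number. Steps that end at compound 3 rest on the limit of < 5% in this assay, at which 1 of the 3 values shown sits, and so give only a smallest size.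

The next change is thiophen-2-yl in place of pyridin-2-yl on an aromatic carbon and it leads to compound 4 `CCCCCCCCc1ccc(OCC(=O)Cn2nnnc2-c2cccs2)cc1` with thiophen-2-yl in place of pyridin-2-yl on an aromatic carbon. Among the measured compounds shown here, no measured compound carries thiophen-2-yl, so only indirect guidance exists.

For the measured compounds named here, three steps bear on it. The step of a number 2 percentage points lower from compound 1 to compound 2 (within the scatter) concerns pyridin-3-yl. The step of a number at least 17 percentage points lower from compound 1 to compound 3 (beyond the scatter) and the step of a number at least 15 percentage points lower from compound 2 to compound 3 (beyond the scatter) both concern pyridin-2-yl, and they set compound 3 apart from the other two. Leaving pyridin-2-yl may therefore recover part of that loss, with compound 2 at 20% as a rough upper guide. The expected step is a number at least 6 percentage points higher from compound 3 to compound 4 (that floor lies within the scatter) in this assay and it may well stay modest. In this assay compound 4 is expected at 11% with a range from 3% to 24% for this estimate.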

Compound 4, percent of the compound remaining: 27%
Estimate against measurement, compound 4: 16 percentage points below; measured number above the stated range.
By their numbers in this assay, from the lowest: compounds 2, 1 and 4 (each within the scatter of the next). At a limit, below all of these: compound 3.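

Compound 3 gives < 5% in this assay, and this is a limit of the assay, not a number. Thiophen-2-yl in place of pyridin-2-yl at this position gives a number at least 22 percentage points higher from compound 3 to compound 4 (beyond the scatter), and that size is only a smallest size: the limit of < 5% in this assay, at which 1 of the 4 values shown sits. The other two comparisons give a number 7 percentage points higher from compound 2 to compound 4 (within the scatter) and a number 5 percentage points higher from compound 1 to compound 4 (within the scatter), so a ring at this position does not by itself bring a compound down to the limit, and among the four compounds only pyridin-2-yl, in compound 3, stands apart from the rest, while thiophen-2-yl, pyridin-3-yl and plain hydrogen cannot be told apart.

The compounds shown do not say why pyridin-2-yl differs from the other groups, since they offer no measurement that separates one possible reason from another. From the compounds shown here alone, it also remains open whether a plain phenyl ring, a furan-2-yl ring or a thiophen-2-yl ring carrying an amine or a carboxylic acid would follow compound 4 or compound 3 at this position, or would leave clearly more of the compound after the incubation.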